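A few compounds are considered here, and "the series" means these few. Any claim that something is new, unique, unknown or untested is made for them only; others in the source may bear on it.

Measured so far: compound 1 `O=C(Nc1cc(F)cc2cccnc12)c1ncccn1`, compound 2 `O=C(Nc1cc(Cl)cc2cccnc12)c1ncccn1` and compound 3 `CC(C)(C)OC(=O)NCCOc1cc(NC(=O)c2ncccn2)c2ncccc2c1`; still to be measured is compound 4 `O=C(Nc1cc(OCCC2CCNCC2)cc2cccnc12)c1ncccn1`.

In a functional assay on PANC-1 cells (Homo sapiens) for inhibition, read by MTT assay, with a stated time of 72 h (on this read-out lower numbers stand for stronger inhibition and higher numbers for weaker inhibition), compound 1 gives 5300 nM, and compound 2 gives 4670 nM; the step of a 1.1-fold lower number from compound 1 to compound 2 (0.05 log units; within the scatter) lies within the scatter. Compound 3 yields only a limit of the assay, > 10000 nM, namely (the limit of > 10000 nM in this assay, at which 1 of the 3 values shown sits). Compound 3 therefore stands beyond every number shown. Compound 4 carries piperidin-4-yl in place of (tert-butoxycarbonyl)amino on a saturated chain carbon, two bonds along the chain from an oxygen on an aromatic ring. Within the data shown here, no measured step touches this change; the single known step, a 1.1-fold lower number from compound 1 to compound 2 (0.05 log units; within the scatter), concerns chloro in place of fluoro and was within the scatter, so it gives no guide to size or direction. Compound 4 is thus expected to sit near the limit, the step of an at least 1.2-fold lower number from compound 3 to compound 4 (0.09 log units; that floor lies within the scatter) being uncertain. The estimate for compound 4 in this assay is 8000 nM, between 2000 nM and 30000 nM.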

Compound 4, half-maximal inhibitory concentration: > 10000 nM
Compound 4: only a limit was reported (the forecaster's own chance of this, stated with the estimate: 40%); middle value at least 1.2-fold (0.09 log units) from the limit.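

In this assay, the change from (tert-butoxycarbonyl)amino to piperidin-4-yl on the chain did not yield a readable number: compound 4, like compound 3, reports only a limit, so the step between them cannot be read. With 2-(piperidin-4-yl)ethoxy on the aromatic carbon instead of a halogen, the result is an at least 2.1-fold higher number from compound 2 to compound 4 (0.33 log units; beyond the scatter) and an at least 1.8-fold higher number from compound 1 to compound 4 (0.27 log units; that floor lies within the scatter). Both side-chain compounds now rest at the same limit: the limit of > 10000 nM in this assay, at which 2 of the 4 values shown sit.

The compounds shown leave open whether a shorter chain ending in a primary amine, or in a carboxylic acid, would give a readable number here.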